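Coumarin ether series: azole spacers and a nitro substituent

The source may report more compounds than this note shows. Statements on the series, on what has been measured and on what is new or still open speak of the compounds shown alone.

Working notes on four compounds that share one core, differing in the five-membered ring that links the core to a phenyl group and in a single substituent on that phenyl. Compound 1 `O=c1ccc2cc(OCc3cc(-c4ccccc4)no3)ccc2o1` and compound 2 `O=c1ccc2cc(OCc3cc(-c4ccccc4[N+](=O)[O-])no3)ccc2o1` carry an isoxazole linker; in a functional assay on HCT-116 cells (Homo sapiens) for cytotoxicity, read by MTT assay, with a stated time of 48 h (on this read-out lower numbers stand for stronger inhibition and higher numbers for weaker inhibition), compound 1 is reported as "not determined" (no result reported) and compound 2 as "not determined" (no result reported), so neither contributes a number. Within the data shown here, compound 3 `O=c1ccc2cc(OCc3cn(-c4ccccc4)nn3)ccc2o1` carries a triazole linker and in this assay compound 3 gives 51500 nM, the only number in the set; no comparison with a measured neighbour is therefore possible.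

Compound 4 `O=c1ccc2cc(OCc3cn(-c4ccccc4[N+](=O)[O-])nn3)ccc2o1` is the nitro analogue of compound 3. The difference, computed from the two structures, is nitro in place of hydrogen on an aromatic carbon, ortho to a large group. With no measured step of this kind in the series, the step from compound 3 to compound 4 is expected to stay within scatter, a 1.1-fold lower number from compound 3 to compound 4 (0.06 log units; within the scatter). Compound 4 is thus estimated at 45000 nM, with a range from 15000 nM to 140000 nM.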

Compound 4, half-maximal inhibitory concentration: 55800 nM
The estimate for compound 4 lay 1.2-fold (0.09 log units) below the measured number, and the stated range covers the measured number.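

In this assay, the series now has its first measured step: phenyl to 2-nitrophenyl on the triazole linker gives a 1.1-fold higher number from compound 3 to compound 4 (0.03 log units; within the scatter). On this aromatic carbon, ortho to a large group, nitro in place of hydrogen therefore does not separate the pair, and this holds for this one substituent on this one linker only. Nothing at hand bears on why the number stays within the scatter.

Compound 1 and compound 2 have no number, so the same step on the isoxazole linker cannot be read, and neither can any comparison of the two linkers. Also open, as far as these compounds go, is whether an amine or a carboxylic acid in place of nitro on this aromatic carbon would give a step beyond the scatter.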